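The source may hold more compounds than are shown below. What is called first, only, known or untested is meant among the compounds shown, and "the series" means these compounds.

Measured compounds:
compound 1 `COc1ccc(/C=C\c2cc(OC)c(OC)c(OC)c2)cc1OCc1ccccc1` gives 59000 nM
compound 2 `COc1ccccc1/C=C/CCCOc1cc(/C=C\c2cc(OC)c(OC)c(OC)c2)ccc1OC` gives 21000 nM
compound 3 `COCOc1ccccc1/C=C/CCCOc1cc(/C=C\c2cc(OC)c(OC)c(OC)c2)ccc1OC` gives 4400 nM

All three were read in a functional assay on MCF7 cells (Homo sapiens) for inhibition, read by MTT assay, with a stated time of 3 days; on this read-out higher numbers stand for weaker inhibition and lower numbers for stronger inhibition. Compound 1 stands at the highest number of the three. The nearest is compound 2, reached by a 2.8-fold lower number from compound 1 to compound 2 (0.45 log units; beyond the scatter), a step beyond the scatter. Compound 3 lies furthest from compound 1, and the gap between them is the widest in the set, though it is built from two changes; the second of those is a 4.8-fold lower number from compound 2 to compound 3 (0.68 log units; beyond the scatter).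

Compound 4 `COc1ccc(/C=C\c2cc(OC)c(OC)c(OC)c2)cc1OCCC/C=C/c1ccc(Br)cc1` is not yet measured in this assay. Against compound 1 it shows (a group of 11 heavy atoms (10 carbon, 1 bromine; one six-membered aromatic ring of carbon only) in place of a group of 6 heavy atoms (6 carbon; one six-membered aromatic ring of carbon only), on a saturated chain carbon bound to an oxygen on an aromatic ring). The step that bears on it is a 2.8-fold lower number from compound 1 to compound 2 (0.45 log units; beyond the scatter), where a group of the same kind, with one six-membered aromatic ring of carbon only and a double bond outside aromatic rings, took the place of phenyl at the same position. That step was modest but beyond the scatter. The entering group of compound 4 carries bromine where compound 2 carried methoxy, and nothing in the set tests that difference. A step of similar size, toward a lower number, is therefore expected: a 2.8-fold lower number from compound 1 to compound 4 (0.45 log units; beyond the scatter). On that basis compound 4 is estimated at 21000 nM, with a range from 8000 nM to 55000 nM.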

Compound 4, half-maximal inhibitory concentration: 37000 nM
The estimate for compound 4 lay 1.8-fold (0.25 log units) below the measured number, within the range that was stated.
By their numbers in this assay, from the lowest: compound 3; then compounds 2, 4 and 1 (each within the scatter of the next, the first and the last beyond it).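

In this assay, the entering group with 4-bromophenyl at its end stays within the scatter of phenyl on the saturated chain carbon bound to an oxygen on an aromatic ring (a 1.6-fold lower number from compound 1 to compound 4 (0.20 log units; within the scatter)), unlike the 2-methoxyphenyl group of compound 2, yet the two ends themselves cannot be separated (a 1.8-fold higher number from compound 2 to compound 4 (0.25 log units; within the scatter)). Among the chain-bearing compounds, only 2-(methoxymethoxy)phenyl stands clearly apart from 4-bromophenyl (an 8.4-fold higher number from compound 3 to compound 4 (0.92 log units; beyond the scatter)), so the end group on the double-bonded chain carbon can matter, though compounds 2 and 4 show no such separation. Nothing available explains these differences.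

The compounds shown leave open whether a hydroxy group or an amine in place of methoxymethoxy on that phenyl ring would keep the number of compound 3. Also open, from the compounds shown here alone, is how a longer chain carrying 2-(methoxymethoxy)phenyl would read.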